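Extending the Amide Chain Once More

The compounds below may be only part of what the source reports. "The series", "measured", "known", "first", "only" and "open" are said of these compounds alone.

In a functional assay on WM164 cells (Homo sapiens) for antiproliferative activity, read by sulforhodamine B assay, with a stated time of 48 h (a higher number here means a weaker inhibitor, a lower number a stronger inhibitor), compound 1 `CCCCCCCCCCNC(=O)[C@@H]1CSC(c2cc(OC)c(OC)c(OC)c2)N1` gives 2100 nM, compound 2 `CCCCCCCCCCCCNC(=O)[C@@H]1CSC(c2cc(OC)c(OC)c(OC)c2)N1` gives 2400 nM, and compound 3 `CCCCCCCCCCCCCCNC(=O)[C@@H]1CSC(c2cc(OC)c(OC)c(OC)c2)N1` gives 1600 nM. Compound 3 therefore stands level with the other two, since its gaps to both lie within the scatter. Compound 4 `CCCCCCCCCCCCCCCCNC(=O)[C@@H]1CSC(c2cc(OC)c(OC)c(OC)c2)N1` keeps the shared core and differs from compound 3 by ethyl in place of hydrogen on a saturated chain carbon, ten or more bonds along the chain from an amide-type nitrogen.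

The same change has been measured twice, as a 1.1-fold higher number from compound 1 to compound 2 (0.06 log units; within the scatter) and as a 1.5-fold lower number from compound 2 to compound 3 (0.18 log units; within the scatter). The butyl change gave a 1.3-fold lower number from compound 1 to compound 3 (0.12 log units; within the scatter). All three steps are small and lie within the scatter, so they show no trend in this assay. No step beyond the scatter is therefore expected, and the estimate is a 1.1-fold higher number from compound 3 to compound 4 (0.05 log units; within the scatter). The data do not show whether this flat behaviour continues for a longer chain. For compound 4 the expected value is 1800 nM, with an estimated range of 900 nM to 3600 nM.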

Compound 4, half-maximal inhibitory concentration: 700 nM
The estimate for compound 4 lay 2.6-fold (0.41 log units) above the measured number; the whole stated range lies above it.
By their numbers in this assay, from the lowest: compound 4; then compounds 3, 1 and 2 (each within the scatter of the next).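

In this assay this position, flat across the shorter chains, now gives steps beyond the scatter: ethyl in place of hydrogen gives a 2.3-fold lower number from compound 3 to compound 4 (0.36 log units; beyond the scatter) and butyl gives a 3.4-fold lower number from compound 2 to compound 4 (0.54 log units; beyond the scatter) while hexyl gives a 3.0-fold lower number from compound 1 to compound 4 (0.48 log units; beyond the scatter) on the same saturated chain carbon. Compound 4 is thus the most potent of the four, the only one separated from all the others, whereas compounds 1, 2 and 3 stand level with one another. Even so, the two readings of the ethyl change cannot be told apart with confidence: the same change on two cores in this assay, a 1.1-fold higher number (0.06 log units; within the scatter) from compound 1 to compound 2 and a 2.3-fold lower number (0.36 log units; beyond the scatter) from compound 3 to compound 4, 2.6-fold (0.42 log units) apart, within the scatter of two such steps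

The compounds shown leave open whether a longer chain would lower the number further or raise it again. They also leave open how an amine or a carboxylic acid on the chain would read in this assay here.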